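This account rests on a few compounds, and the source may have more. Where it says the series, first, only, none or still open, it means among the compounds named here.

Compound 1 `CCC1(Cc2ccccc2)OS(=O)(=O)C=C1OCc1ccc(Cl)cc1` gives >= 50000 nM in an ADME assay on HEL cells (Homo sapiens) for cytotoxicity, with a stated time of 3 days; on this read-out higher numbers stand for lower toxicity in this test and lower numbers for higher toxicity in this test. That value is a limit of the assay, not a number. Compound 2 `CC(C)CC1(Cc2ccccc2)OS(=O)(=O)C=C1OCc1ccccc1` gives >= 80000 nM in this assay. That value, too, is a limit of the assay.

Compound 1 therefore stands at a limit only; of the two values shown, both are limits, one sitting at the limit of >= 50000 nM in this assay, at which 1 of the 2 values shown sits, and the other at the limit of >= 80000 nM in this assay, at which 1 of the 2 values shown sits. Within the data shown here, no step between the measured compounds is given, so the two values show nothing more than that neither compound reached a measurable cytotoxic concentration within the tested range.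

Compound 3 `C=CCOC1=CS(=O)(=O)OC1(CC)Cc1ccccc1` differs from compound 1 by vinyl in place of 4-chlorophenyl on a saturated chain carbon bound to an oxygen on an unsaturated carbon. In this assay the step that the limit leaves unreadable from compound 1 to compound 3 is expected to be none beyond the scatter. Since compound 1 sits at a limit, compound 3 is expected most likely to return a limit as well. Compound 3 is estimated at 60000 nM, in the range 30000 nM to 150000 nM.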

Compound 3, minimum cytotoxic concentration: 80000 nM
Compound 3: the middle estimate sits 1.3-fold (0.12 log units) below what was measured; measured number inside the range.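

Among these compounds, compound 1 stands only at a limit in this assay, and no step from it to compound 3 can be read. The compounds shown leave open whether vinyl in place of 4-chlorophenyl shifts the minimum cytotoxic concentration at all, and where compound 1 itself would register a measured value.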